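Methoxy for fluoro on the amine-linked ring of compound 2

The compounds below may be only part of what the source reports. "The series", "measured", "known", "first", "only" and "open" are said of these compounds alone.

Of the compounds shown here, two have numbers so far. Compound 1 `CCS(=O)(=O)Nc1cc(-c2ccc3ncnc(Nc4ccc(F)cc4F)c3c2)cnc1OC` gives 1610 nM in a functional assay on MCF7 cells (Homo sapiens) for cytotoxicity, read by sulforhodamine B assay, with a stated time of 72 h; on this read-out lower numbers stand for stronger inhibition and higher numbers for weaker inhibition. Compound 2 `CCS(=O)(=O)Nc1cc(-c2ccc3ncnc(Nc4ccc(F)nc4)c3c2)cnc1OC` gives 5390 nM in this assay, the higher of the two numbers; the step between them, a 3.3-fold higher number from compound 1 to compound 2 (0.52 log units; beyond the scatter), came with 6-fluoropyridin-3-yl in place of 2,4-difluorophenyl on a nitrogen on an aromatic ring.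

Compound 3 `CCS(=O)(=O)Nc1cc(-c2ccc3ncnc(Nc4ccc(OC)nc4)c3c2)cnc1OC` is not yet measured. It differs from compound 2 by methoxy in place of fluoro on an aromatic carbon, read one bond further out as 6-fluoropyridin-3-yl to 6-methoxypyridin-3-yl. Among the compounds with values here, no measured step bears on this exchange; the single measured step concerns another part of the molecule and gives no guide to size or direction. In this assay the expected step from compound 2 to compound 3 is therefore none beyond the scatter, a 1.1-fold lower number from compound 2 to compound 3 (0.03 log units; within the scatter), with wide uncertainty. Compound 3 is estimated at 5000 nM, between 1800 nM and 14000 nM.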

Compound 3, half-maximal inhibitory concentration: 3770 nM
Estimate against measurement, compound 3: 1.3-fold (0.12 log units) above; the range from low to high includes it.
By their numbers in this assay, from the lowest: compound 1; then compounds 3 and 2 (each within the scatter of the next).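

In this assay, methoxy and fluoro on the aromatic carbon next to the ring nitrogen cannot be told apart: a 1.4-fold lower number from compound 2 to compound 3 (0.16 log units; within the scatter). Changing this substituent therefore does not close the gap to compound 1, which remains with the methoxy compound: a 2.3-fold higher number from compound 1 to compound 3 (0.37 log units; beyond the scatter). No available evidence accounts for either step.

Going by these compounds, whether an amine or a longer chain such as ethoxy on the same carbon would give a number distinct from those of compound 2 and compound 3 remains open. Also open, on these data alone, is how much of the gap to compound 1 goes with the ring nitrogen and how much with the fluoro pattern of 2,4-difluorophenyl, a question that a plain phenyl or a 4-fluorophenyl on the amine nitrogen could address.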